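The source may report more compounds than this note shows. Statements on the series, on what has been measured and on what is new or still open speak of the compounds shown alone.

Compound 1 `c1csc(CNc2ncnc3c2ncn3C2CCCO2)c1`: 108%
Compound 2 `Clc1nc(NCc2ccco2)c2ncn(C3CCCO3)c2n1`: 106%

Both numbers come from an ADME assay on NHDF cells (Homo sapiens) for cytotoxicity, read by neutral red uptake, with a stated time of 24 h, tested at 62.5 uM; a lower number here means a weaker effect, a higher number a stronger effect of the compound at the concentration tested. There compound 2 gives 106%, and compound 1 gives 108%, a number within the usual scatter of that of compound 2, so the two cannot be ordered. Compound 3 `Clc1nc(NCC2CCCO2)c2ncn(C3CCCO3)c2n1` has not yet been measured. It differs from compound 2 in one place: oxolan-2-yl in place of furan-2-yl on a saturated chain carbon bound to a nitrogen on an aromatic ring. With two measured compounds that cannot be told apart, no step beyond the scatter is expected in this assay for compound 3. The step expected from this change is a number 2 percentage points lower from compound 2 to compound 3 (within the scatter), small in either direction. Compound 3 is therefore estimated to give 104%, between 90% and 115%.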

Compound 3, a percentage reported as activity, at one concentration (the size of the read-out at that concentration, not a potency): 102%
Estimate against measurement, compound 3: 2 percentage points above; the measured number falls inside the stated range.
By their numbers in this assay, from the lowest: compounds 3, 2 and 1 (each within the scatter of the next).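

In this assay the change gives a number 4 percentage points lower from compound 2 to compound 3 (within the scatter) and so does not separate the aromatic furan-2-yl from the non-aromatic oxolan-2-yl on a saturated chain carbon bound to a nitrogen on an aromatic ring. At this place, then, saturating the five-membered ring gives no step beyond the scatter in this read-out. No measurement shown offers an explanation for this result. Still open, going by these compounds, is whether an open chain such as methoxyethyl, or a ring bearing an amine or a carboxylic acid, would behave the same way at this place.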